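A few compounds are considered here, and "the series" means these few. Any claim that something is new, unique, unknown or untested is made for them only; others in the source may bear on it.

Measured compounds:
compound 1, `COc1ccc(C2C(C(=O)OCc3ccccn3)=C(C)NC3=C2C(=O)CCC3)cc1`: 1.9
compound 2, `CC1=C(C(=O)OCc2cccnc2)C(c2ccc(C#N)cc2)C2=C(CCCC2=O)N1`: 1.36
compound 3, `CC1=C(C(=O)OCc2cccnc2)C(c2ccc([N+](=O)[O-])cc2)C2=C(CCCC2=O)N1`: 1.51

In a physicochemical assay for lipophilicity, measured as octanol-water partition (a lower number here means a more polar compound, a higher number a more lipophilic compound), compound 3 stands second highest of the three numbers. Its nearest neighbour is compound 2, whose value lies within the scatter of compound 3, so the two cannot be told apart; compound 1 lies furthest away, with a number beyond the scatter above compound 3. Compound 4, `COc1ccc(C2C(C(=O)OCc3cccnc3)=C(C)NC3=C2C(=O)CCC3)cc1`, is not yet measured. It differs from compound 3 in one place: methoxy in place of nitro on an aromatic carbon. For the measured compounds named here, only one measured step bears on this change, and only loosely: a number 0.15 log units higher from compound 2 to compound 3 (within the scatter), a swap of one group on an aromatic carbon that stayed within the scatter. Going by the values given here, no measured pair shows methoxy against nitro directly, but compound 1 carries a methoxy group and gives the highest number of the three. A modest rise is therefore expected for compound 4 in this assay, a number 0.29 log units higher from compound 3 to compound 4 (within the scatter). The estimate for compound 4 is 1.8, with a range from 1.5 to 2.1.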

Compound 4, partition coefficient: 1.54
Beside the measured number, compound 4's estimate is 0.26 log units above it; the range from low to high includes it.
By their numbers in this assay, from the lowest: compounds 2, 3 and 4 (each within the scatter of the next); then compound 1.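

In this assay, putting methoxy in place of nitro on this aromatic carbon, para to a large group, gives no readable change (a number 0.03 log units higher from compound 3 to compound 4 (within the scatter)), and methoxy in place of cyano gives none either (a number 0.18 log units higher from compound 2 to compound 4 (within the scatter)). Nitrile, nitro and methoxy at this position therefore cannot be told apart here, so the methoxy group alone does not go with a higher number. For the compounds shown here, the one step beyond the scatter lies in the other place, pyridin-3-yl in place of pyridin-2-yl (a number 0.36 log units lower from compound 1 to compound 4 (beyond the scatter)), and nothing measured here explains that step.

Pyridin-2-yl appears here only alongside methoxy, so it remains open whether the same step would appear with nitro or nitrile. From the compounds shown here alone, it is also open whether an amine or a carboxylic acid on the same aromatic carbon would stay within the scatter of these three groups.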